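The compounds below may be only part of what the source reports. "The series", "measured", "known", "first", "only" and "open" are said of these compounds alone.

Measured compounds:
compound 1 `O=C(/N=C(/NC(=O)c1cc(-c2ccccc2)nc2ccccc12)[Se]Cc1ccccc1)c1cc(-c2ccccc2)nc2ccccc12`: 78900 nM
compound 2 `O=C(/N=C(/NC(=O)c1cccs1)[Se]Cc1ccccc1)c1cccs1`: 81500 nM
compound 3 `CS/C(=N\C(=O)c1cccs1)NC(=O)c1cccs1`: > 100000 nM

In a functional assay on HepG2 cells (Homo sapiens) for cytotoxicity, read by MTT assay, with a stated time of 72 h (on this read-out higher numbers stand for lower toxicity in this test and lower numbers for higher toxicity in this test), compound 1 gives 78900 nM and compound 2 gives 81500 nM; these two sit within the scatter of each other. For compound 3 the result is a limit of the test, > 100000 nM, so no number is known. How the core of compound 1 differs from that of compound 2 is not broken down here. Going from compound 2 to compound 3 makes one change: a group of 2 heavy atoms (1 carbon, 1 sulfur; no ring) in place of a group of 8 heavy atoms (7 carbon, 1 selenium; one six-membered aromatic ring of carbon only), on a carbon with a double bond to nitrogen The step in this assay is an at least 1.2-fold higher number from compound 2 to compound 3 (0.08 log units; that floor lies within the scatter). Compound 3 thus sits at the limit of > 100000 nM in this assay, at which 1 of the 3 values shown sits. Compound 4 `CS/C(=N\C(=O)c1cc(-c2ccccc2)nc2ccccc12)NC(=O)c1cc(-c2ccccc2)nc2ccccc12` is not yet measured; it arises from compound 1 by the same change: a group of 2 heavy atoms (1 carbon, 1 sulfur; no ring) in place of a group of 8 heavy atoms (7 carbon, 1 selenium; one six-membered aromatic ring of carbon only), on a carbon with a double bond to nitrogen Compound 4 is expected to move by a 1.5-fold higher number from compound 1 to compound 4 (0.18 log units; within the scatter) because the step of an at least 1.2-fold higher number from compound 2 to compound 3 (0.08 log units; that floor lies within the scatter) starts from compound 2 at 81500 nM, within the scatter of compound 1. Compound 4 is therefore estimated at 120000 nM, between 70000 nM and 250000 nM, and may well be reported only as a limit.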

Compound 4, concentration lethal to 50% of the cells: > 100000 nM
Compound 4: a limit, no number; the forecaster's own chance of this, stated with the estimate: 65%; the middle value lies beyond the limit too.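

On the core of compound 1, putting methylsulfanyl in place of the selenium-containing group, on a carbon with a double bond to nitrogen, gives an at least 1.2-fold higher number from compound 1 to compound 4 (0.10 log units; that floor lies within the scatter) in this assay. Compound 4 reads > 100000 nM, which is a limit of the test and not a number. The change ends at this limit on both cores, so the data show no real shift on either core and cannot show whether its size carries from one core to the other: the same change on two cores in this assay, an at least 1.2-fold higher number (0.08 log units; that floor lies within the scatter) from compound 2 to compound 3 and an at least 1.2-fold higher number (0.10 log units; that floor lies within the scatter) from compound 1 to compound 4; the limit leaves it open whether they differ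

A benzylsulfanyl group in the same place would separate the part played by the selenium from that of the ring. As far as these compounds go, it also stays open whether an amine or a longer chain there would give a number inside the range of the test.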